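Swapping a Chlorine for a Hydroxyl on the Aryl Ring

The compounds below may be only part of what the source reports. "The series", "measured", "known", "first", "only" and "open" are said of these compounds alone.

Compound 1 `O=C(N/N=C/c1cccc(F)c1)c1cccnc1Nc1cccc(C(F)(F)F)c1` and compound 2 `O=C(N/N=C/c1ccc(Cl)cc1)c1cccnc1Nc1cccc(C(F)(F)F)c1` share one core and differ only in the ring on a carbon with a double bond to nitrogen. In a functional assay on the whole organism (strain Wistar) for inhibition, with Rattus norvegicus as the target, read by paw edema, with a stated time of 2 h, at a dose of 10 mg/kg by the intraperitoneal route (on this read-out lower numbers stand for less inhibition and higher numbers for more inhibition at the one dose given (going by the name of the read-out)), compound 1 gives 52.8%, and compound 2 gives 52.8%; the step of no change at the digits printed from compound 1 to compound 2 (within the scatter) stays within the scatter, so compound 2 stands level with compound 1. Compound 3 `O=C(N/N=C/c1cccc(O)c1)c1cccnc1Nc1cccc(C(F)(F)F)c1` differs from compound 2 by 3-hydroxyphenyl in place of 4-chlorophenyl on a carbon with a double bond to nitrogen. Among the compounds with values here, the only measured step changed that same ring without effect, so the expected step is a number 2.8 percentage points lower from compound 2 to compound 3 (within the scatter), nothing beyond the scatter. Compound 3 is estimated at 50%, between 35% and 65%.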

Compound 3, a percentage reported as inhibition, in the whole organism at one dose (the size of the read-out at that dose, not a potency): 65.4%
Compound 3: the middle estimate sits 15.4 percentage points below what was measured, outside the stated range (above it).
By their numbers in this assay, from the lowest: compounds 1 and 2 (each within the scatter of the next); then compound 3.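

In this assay, the ring on a carbon with a double bond to nitrogen turns out not to be indifferent to what it carries: 3-hydroxyphenyl in place of 4-chlorophenyl gives a number 12.6 percentage points higher from compound 2 to compound 3 (beyond the scatter). The cleaner comparison, hydroxy in place of fluoro on an aromatic carbon, gives a number 12.6 percentage points higher from compound 1 to compound 3 (beyond the scatter), so the hydroxy group goes with the higher number even when nothing else on the ring differs. Nothing available explains this gain. Still open, from the compounds shown here alone, is whether an amine or a methoxy group on that aromatic carbon would match hydroxy.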